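A few compounds are considered here, and "the series" means these few. Any claim that something is new, unique, unknown or untested is made for them only; others in the source may bear on it.

Of the compounds shown here, three sharing one core have been measured in a functional assay on HepG2 cells (Homo sapiens) for antiproliferative activity, read by MTT assay; on this read-out lower numbers stand for stronger inhibition and higher numbers for weaker inhibition. Compound 1 `Nc1c(C(=O)NC2CCCC2)oc2nc(-c3ccccc3)cc(C(F)(F)F)c12`, with a five-membered non-aromatic ring of carbon only on its amide-type nitrogen, gives 32400 nM. Compound 2 `Nc1c(C(=O)N/N=C/c2ccccc2)oc2nc(-c3ccccc3)cc(C(F)(F)F)c12` gives 13100 nM, and compound 3 `Nc1c(C(=O)N/N=C/c2ccc(Cl)cc2)oc2nc(-c3ccccc3)cc(C(F)(F)F)c12` gives 12100 nM. Chloro in place of hydrogen on an aromatic carbon accounts for a 1.1-fold lower number from compound 2 to compound 3 (0.03 log units; within the scatter), so compound 3 stands level with compound 2, and both lie clearly under compound 1.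

Compound 4 `CCCNC(=O)c1oc2nc(-c3ccccc3)cc(C(F)(F)F)c2c1N` has not yet been measured. Its difference from compound 3 is a group of 3 heavy atoms (3 carbon; no ring) in place of a group of 9 heavy atoms (7 carbon, 1 nitrogen, 1 chlorine; one six-membered aromatic ring of carbon only), on an amide-type nitrogen. The most useful evidence is a 2.7-fold lower number from compound 1 to compound 3 (0.43 log units; beyond the scatter), supported by a 2.5-fold lower number from compound 1 to compound 2 (0.39 log units; beyond the scatter). Both steps replace the carbon-only ring group of compound 1 with a larger group holding an aromatic ring, and both are modest. Propyl also holds carbon only, so compound 4 reverses that kind of exchange, although no measured compound carries propyl itself and the comparison is only an analogy. A modest move back towards a higher, weaker number is therefore expected, estimated as a 2.5-fold higher number from compound 3 to compound 4 (0.39 log units; beyond the scatter). For compound 4 the estimated value is 30000 nM, with an expected range of 14000 nM to 60000 nM.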

Compound 4, half-maximal inhibitory concentration: 37400 nM
Compound 4: middle estimate off by 1.2-fold (0.10 log units), on the low side, and the stated range covers the measured number.
By their numbers in this assay, from the lowest: compounds 3 and 2 (each within the scatter of the next); then compounds 1 and 4 (each within the scatter of the next).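

Propyl, which has no ring, and cyclopentyl, which has one, give the same reading on the amide-type nitrogen in this assay: there is a 1.2-fold higher number from compound 1 to compound 4 (0.06 log units; within the scatter), so a carbon-only ring on its own makes no visible difference here. Against propyl, the two groups holding an aromatic ring remain apart, as a 2.9-fold higher number from compound 2 to compound 4 (0.46 log units; beyond the scatter) and a 3.1-fold higher number from compound 3 to compound 4 (0.49 log units; beyond the scatter) show, and among these four compounds the divide therefore runs between the carbon-only groups and the larger groups with an aromatic ring, with no compound going against it. No measurement offered here gives a reason for this divide.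

The compounds shown leave open whether the aromatic ring alone accounts for the divide, or whether the nitrogen and the double bond that link it to the amide-type nitrogen also count, a question that a benzyl group would help to settle. They also leave open how a longer chain such as hexyl, or a propyl chain ending in an amine or a carboxylic acid, would read in this assay.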